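Cytotoxicity of a phenoxy-linked core: methyl removal

This account rests on a few compounds, and the source may have more. Where it says the series, first, only, none or still open, it means among the compounds named here.

Compound 1 `N#Cc1ccc(Nc2nc(Oc3ccccc3Cl)c3ccccc3n2)cc1`: 38000 nM
Compound 2 `Cc1cccc(Oc2nc(Nc3ccc(C#N)cc3)nc3ccccc23)c1`: 355000 nM

In an ADME assay on MT4 cells (Homo sapiens) for cytotoxicity, read by MTT assay, with a stated time of 4 days (on this read-out lower numbers stand for higher toxicity in this test and higher numbers for lower toxicity in this test), compound 2 gives the highest of the two numbers, with compound 1 the nearer at 38000 nM. Among the compounds with values here, the only measured step, a 9.3-fold higher number from compound 1 to compound 2 (0.97 log units; beyond the scatter), exchanges one aryl group for another and does not directly bear on the present change. Compound 3 `N#Cc1ccc(Nc2nc(Oc3ccccc3)c3ccccc3n2)cc1` differs from compound 2 by hydrogen in place of methyl on an aromatic carbon. Within the data shown here, with no step of this kind measured, a change within the scatter is expected, a 1.6-fold lower number from compound 2 to compound 3 (0.21 log units; within the scatter). Compound 3 is therefore estimated at 220000 nM, with a range from 70000 nM to 600000 nM.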

Compound 3, half-maximal cytotoxic concentration: 370000 nM
For compound 3 the middle estimate is 1.7-fold (0.23 log units) below the measured one; the measured number falls inside the stated range.
By their numbers in this assay, from the lowest: compound 1; then compounds 2 and 3 (each within the scatter of the next).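

In this assay hydrogen in place of methyl gives a 1.0-fold higher number from compound 2 to compound 3 (0.02 log units; within the scatter), so going from 3-methylphenoxy to phenoxy leaves the number within the scatter. Hydrogen in place of chloro gives a 9.7-fold higher number from compound 1 to compound 3 (0.99 log units; beyond the scatter), which sets compound 1, with its 2-chlorophenyl, apart from both other compounds. Nothing available explains this contrast. The compounds shown leave open whether the contrast lies in the group or in its place, as chloro and methyl occupy different carbons. They also leave open whether an amine or a methoxy group on that ring would stay within the scatter of compound 3.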